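Series notes: 3-hydroxypropyl for methylsulfanyl on the chain carbon

A few compounds are considered here, and "the series" means these few. Any claim that something is new, unique, unknown or untested is made for them only; others in the source may bear on it.

In a functional assay for inhibition, with Homo sapiens as the target (a lower number here means a stronger inhibitor, a higher number a weaker inhibitor), compound 1 `O=C(O)COc1cccc(/C=C\c2nc(-c3ccccc3)c(-c3ccccc3)o2)c1` gives 180 nM. In this assay compound 2 `CCOC(=O)C(Cc1cccc(OCC(=O)O)c1OC)c1nc(-c2ccccc2)c(-c2ccccc2)o1` gives 1180 nM. In this assay compound 3 `CSC(Cc1cccc(OCC(=O)O)c1)c1nc(-c2ccccc2)c(-c2ccccc2)o1` gives 1300 nM; this is the highest of the three numbers, with compound 2 within the usual scatter of it and compound 1 beyond the scatter on the lower side. Compound 4 `O=C(O)COc1cccc(CC(CCCO)c2nc(-c3ccccc3)c(-c3ccccc3)o2)c1` is not yet measured. Its change from compound 3: 3-hydroxypropyl in place of methylsulfanyl on a saturated chain carbon bound to an aromatic carbon and a saturated chain carbon. For the measured compounds named here, no measured pair shares this kind of change, so the size of the step has no anchor in the data. The expected step, a 1.3-fold lower number from compound 3 to compound 4 (0.11 log units; within the scatter), is small and in no direction beyond the scatter. Compound 4 is estimated at 1000 nM, with a range from 350 nM to 2800 nM.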

Compound 4, half-maximal inhibitory concentration: 1700 nM
The estimate for compound 4 lay 1.7-fold (0.23 log units) below the measured number, and the stated range covers the measured number.
By their numbers in this assay, from the lowest: compound 1; then compounds 2, 3 and 4 (each within the scatter of the next).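

On the saturated chain carbon bound to an aromatic carbon and a saturated chain carbon, 3-hydroxypropyl in place of methylsulfanyl gives a 1.3-fold higher number from compound 3 to compound 4 (0.12 log units; within the scatter) in this assay. This position therefore accepts the swap, including the added hydrogen-bond donor, with no difference that can be told from the scatter. Nothing measured here bears on the reason for this result.

Going by these compounds, whether an amine, a carboxylic acid or a chain longer than 3-hydroxypropyl on this carbon would move the number beyond the scatter remains open. For the compounds shown here, also open is what sets compound 1 apart, as no one-place step links it to the other compounds.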